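Benzyl substituent swap, from compound 3 to compound 4

The source may hold more compounds than are shown below. What is called first, only, known or untested is meant among the compounds shown, and "the series" means these compounds.

Compound 3 `CCOC(=O)c1sc(-c2ccccc2)nc1N1CCC(NCc2ccc(C(F)(F)F)cc2)CC1` stands highest of the three measured compounds in an ADME assay on RAW264.7 cells (Mus musculus) for cytotoxicity, read by MTT assay, with a stated time of 72 h, tested at 50 uM (on this read-out higher numbers stand for more inhibition at the one concentration tested (going by the name of the read-out) and lower numbers for less inhibition), giving 22.7%. In this assay compound 1 `CCOC(=O)c1sc(-c2ccccc2)nc1N1CCC(NCc2ccc(F)cc2)CC1` gives 6.23%, and compound 2 `CCOC(=O)c1sc(-c2ccccc2)nc1N1CCC(NCc2ccc(OC)cc2)CC1` gives 8.4%. The steps of a number 16.5 percentage points higher from compound 1 to compound 3 (beyond the scatter) and a number 14.3 percentage points higher from compound 2 to compound 3 (beyond the scatter) both lie beyond the scatter, whereas a number 2.2 percentage points higher from compound 1 to compound 2 (within the scatter) lies within it. Compound 4 `CCOC(=O)c1sc(-c2ccccc2)nc1N1CCC(NCc2ccc(Cl)c(Cl)c2)CC1` has not yet been measured in this assay; relative to compound 3 it carries 3,4-dichlorophenyl in place of 4-(trifluoromethyl)phenyl on a saturated chain carbon bound to an amine nitrogen. Among the measured compounds shown here, none of the measured steps covers two chlorines or a change at two aromatic carbons at once, so no direct precedent exists; the measured steps only show that exchanging the group at a single aromatic carbon moved the read-out by no more than a modest amount. For compound 4 the expected step in this assay is therefore a number 2.7 percentage points lower from compound 3 to compound 4 (within the scatter), with no direction claimed beyond the scatter. The estimate for compound 4 in this assay is 20%, with a range from 5% to 40%.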

Compound 4, a percentage reported as inhibition, at one concentration (the size of the read-out at that concentration, not a potency): 18.1%
Beside the measured number, compound 4's estimate is 1.9 percentage points above it; measured number inside the range.
By their numbers in this assay, from the lowest: compounds 1, 2, 4 and 3 (each within the scatter of the next, the first and the last beyond it).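

Notes on the benzyl substituent in this assay: this position accepts a change at two aromatic carbons, 4-(trifluoromethyl)benzyl to 3,4-dichlorobenzyl, with a number 4.6 percentage points lower from compound 3 to compound 4 (within the scatter), so the upper part of the small range seen here is not confined to trifluoromethyl. The 3,4-dichlorobenzyl group does not separate clearly from 4-methoxybenzyl, with a number 9.7 percentage points higher from compound 2 to compound 4 (within the scatter), but it does separate from 4-fluorobenzyl, with a number 11.9 percentage points higher from compound 1 to compound 4 (beyond the scatter), which leaves compound 4 within the scatter of two compounds that lie beyond the scatter of each other. No measurement is available that bears on what underlies these steps.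

All four compounds keep the shared core and a substituted benzyl group on the amine nitrogen. Still open, from the compounds shown here alone, is how the read-out responds to a carboxylic acid or an amine on the aromatic ring, or to a longer chain in place of the benzyl group.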